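This account rests on a few compounds, and the source may have more. Where it says the series, first, only, none or still open, it means among the compounds named here.

Of the compounds shown here, three of one family have been tested in a functional assay on M21 cells (Homo sapiens) for antiproliferative activity, read by sulforhodamine B assay, with a stated time of 48 h; on this read-out higher numbers stand for weaker inhibition and lower numbers for stronger inhibition. Compound 1, `CCCC(=O)Nc1ccc(S(=O)(=O)Oc2ccccc2C(C)C)cc1`, gives 6100 nM in this assay. Compound 2, `CCCC(=O)Nc1ccc(S(=O)(=O)Oc2ccccc2I)cc1`, gives 9000 nM; it differs from compound 1 only in one place: iodo in place of isopropyl on an aromatic carbon. Alongside that change, this assay moves a 1.5-fold higher number from compound 1 to compound 2 (0.17 log units; within the scatter). Compound 3, `CCCCCC(=O)Nc1ccc(S(=O)(=O)Oc2ccccc2C(C)C)cc1`, gives 6700 nM; it differs from compound 1 in a separate place: ethyl in place of hydrogen on a saturated chain carbon, three bonds along the chain from a carbonyl carbon. That difference goes with a move of a 1.1-fold higher number from compound 1 to compound 3 (0.04 log units; within the scatter).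

Compound 4, `CCCCCC(=O)Nc1ccc(S(=O)(=O)Oc2ccccc2I)cc1`, has not yet been measured. It stands to compound 3 as compound 2 stands to compound 1, the change being (iodo in place of isopropyl on an aromatic carbon). The place of this change is described in the same words for both pairs, so it is the same change, made twice among these compounds. From compound 3 to compound 4 the expected step in this assay is a 1.4-fold higher number from compound 3 to compound 4 (0.15 log units; within the scatter), because compound 1 to compound 2 gave a 1.5-fold higher number from compound 1 to compound 2 (0.17 log units; within the scatter), and the chain change from compound 1 to compound 3 gave a 1.1-fold higher number from compound 1 to compound 3 (0.04 log units; within the scatter). Compound 4 is therefore estimated at 9500 nM, expected to lie between 5000 nM and 19000 nM.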

Compound 4, half-maximal inhibitory concentration: 11000 nM
Compound 4: the middle estimate sits 1.2-fold (0.06 log units) below what was measured, within the range that was stated.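

In this assay, iodo in place of isopropyl gives a 1.6-fold higher number from compound 3 to compound 4 (0.22 log units; within the scatter), and this change reads much the same on both cores: the same change on two cores in this assay, a 1.5-fold higher number (0.17 log units; within the scatter) from compound 1 to compound 2 and a 1.6-fold higher number (0.22 log units; within the scatter) from compound 3 to compound 4, 1.1-fold (0.05 log units) apart, within the scatter of two such steps

Ethyl in place of hydrogen on the chain gives a 1.2-fold higher number from compound 2 to compound 4 (0.09 log units; within the scatter), and this change also carries over from one core to the other: the same change on two cores in this assay, a 1.1-fold higher number (0.04 log units; within the scatter) from compound 1 to compound 3 and a 1.2-fold higher number (0.09 log units; within the scatter) from compound 2 to compound 4, 1.1-fold (0.05 log units) apart, within the scatter of two such steps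

Within the data shown here, each step lies within the usual scatter of repeated measurements, so this agreement shows only that neither change produces a step that stands clear of the scatter on these two cores; it does not show that a real effect of fixed size is being carried across, and it says nothing about other cores.

The compounds shown leave open whether steps large enough to stand clear of the scatter would carry over in the same way, for example with an amine or a carboxylic acid in place of the iodo group. Among these compounds, they also leave open what a longer chain than the one in compound 3 would do.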